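Will a morpholine end group change lung stability?

This account rests on a few compounds, and the source may have more. Where it says the series, first, only, none or still open, it means among the compounds named here.

Measured so far in an ADME assay on the whole organism (lung, Rattus norvegicus) for metabolic stability, read by LC-MS, with a stated time of 24 h (on this read-out higher numbers stand for a more stable compound and lower numbers for a less stable compound), for three compounds:
- Compound 1 `Cc1csc2cc([C@H](C)Nc3ncnc(N)c3C#N)c(-c3cccc(CN(C)CCCCN(C)Cc4ccccc4)c3)c(=O)n12` (7.4%)
- Compound 2 `Cc1csc2cc([C@H](C)Nc3ncnc(N)c3C#N)c(-c3cccc(CN4CCC(CN(C)Cc5ccccn5)CC4)c3)c(=O)n12` (5.2%)
- Compound 3 `Cc1csc2cc([C@H](C)Nc3ncnc(N)c3C#N)c(-c3cccc(CN4CCC(N(C)CCC(F)(F)F)CC4)c3)c(=O)n12` (3.5%)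

The three values lie within the usual scatter of one another, so compound 1 cannot be told apart from compound 2 or compound 3 on these numbers. All three stand low in this assay and little of each compound remains.

Compound 4 `Cc1csc2cc([C@H](C)Nc3ncnc(N)c3C#N)c(-c3cccc(CN(C)CCCCN4C[C@@H](C)O[C@@H](C)C4)c3)c(=O)n12` keeps the core and the chain of compound 1 and changes one end group (2,6-dimethylmorpholin-4-yl in place of benzyl(methyl)amino on a saturated chain carbon, four bonds along the chain from an amine nitrogen). An aromatic ring of carbon only leaves and a non-aromatic ring enters.

For the measured compounds named here, no measured step covers this exact swap, and no data show what 2,6-dimethylmorpholin-4-yl does here. The closest evidence is a change of another outer amine group (a number 1.7 percentage points lower from compound 2 to compound 3 (within the scatter)) and that step stays within the scatter. One step is thin support, but on this evidence no change beyond the scatter is expected in this assay for the new swap. The estimated step is a number 1.4 percentage points lower from compound 1 to compound 4 (within the scatter) and so it is no real move in either direction. Compound 4 is expected at 6% (estimated range 2% to 14%).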

Compound 4, percent of the compound remaining: 3.9%
The estimate for compound 4 lay 2.1 percentage points above the measured number; measured number inside the range.
By their numbers in this assay, from the lowest: compounds 3, 4, 2 and 1 (each within the scatter of the next).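

In this assay, putting 2,6-dimethylmorpholin-4-yl in place of benzyl(methyl)amino, on a saturated chain carbon, four bonds along the chain from an amine nitrogen, gives a number 3.5 percentage points lower from compound 1 to compound 4 (within the scatter). For the compounds shown here, this is the first measured change at this end of the chain of compound 1, and it shows that an aromatic ring of carbon only can give way to a non-aromatic ring with 2 hetero atoms without a move in this read-out that stands beyond the usual scatter. Nothing at hand bears on which part of these molecules is lost in the lung, or on why so little of compound 1 and compound 4 remains after the stated time.

Still open, as far as these compounds go, is whether another end group at this place, such as a morpholine without the two methyl groups, a primary amine or a carboxylic acid, would lift the number clear of the scatter. Equally open, from the compounds shown here alone, is whether a shorter or longer chain carrying the same 2,6-dimethylmorpholin-4-yl group would leave more of the compound in the lung.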